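Trimming the Amine on a Shared Core

A few compounds are considered here, and "the series" means these few. Any claim that something is new, unique, unknown or untested is made for them only; others in the source may bear on it.

Measured compounds:
compound 1, `CCN(CCC#N)c1nc(C)nc2c(-c3c(C)cc(OC)cc3OC)c(C)nn12`, gives 2.48 nM in an assay on cell membranes for displacement of a labelled ligand from corticotropin-releasing factor receptor 1 (Rattus norvegicus); on this read-out higher numbers stand for weaker inhibition and lower numbers for stronger inhibition
compound 2, `CCC(CC)Nc1nc(C)nc2c(-c3c(C)cc(OC)cc3OC)c(C)nn12`, gives 5 nM in this assay

Among the compounds with values here, compound 2 carries the larger of these two numbers, yet its only neighbour, compound 1, lies a step of a 2.0-fold higher number from compound 1 to compound 2 (0.30 log units; within the scatter) away, within the scatter, so the two cannot be told apart. Compound 3, `CCCN(C)c1nc(C)nc2c(-c3c(C)cc(OC)cc3OC)c(C)nn12`, differs from compound 2 by methyl(propyl)amino in place of (pentan-3-yl)amino on an aromatic carbon. Within the data shown here, the one step that bears on this, from compound 1 to compound 2, also swapped one amine for another and stayed within the scatter. A step in this assay no larger than the scatter, in no set direction, is therefore expected. Compound 3 is expected to give 5 nM, between 1.5 nM and 17 nM. That expectation amounts to a step of no change at the digits printed from compound 2 to compound 3 (within the scatter).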

Compound 3, half-maximal inhibitory concentration: 6.48 nM
For compound 3 the middle estimate is 1.3-fold (0.11 log units) below the measured one; measured number inside the range.
By their numbers in this assay, from the lowest: compounds 1, 2 and 3 (each within the scatter of the next, the first and the last beyond it).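

In this assay, losing the one hydrogen-bond donor of (pentan-3-yl)amino for the none of methyl(propyl)amino gives a 1.3-fold higher number from compound 2 to compound 3 (0.11 log units; within the scatter) and so no readable change, which means that a donor on this amine is not needed for values of this size. Within the data shown here, replacing the (2-cyanoethyl)(ethyl)amino of compound 1 with methyl(propyl)amino gives a 2.6-fold higher number from compound 1 to compound 3 (0.42 log units; beyond the scatter) and is the first step at this position to pass the scatter, though only modestly. Nothing measured here explains either step. As far as these compounds go, how a ring amine such as morpholine would compare at this position remains open, as does a longer chain such as dibutylamino.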